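The compounds below may be only part of what the source reports. "The series", "measured", "known", "first", "only" and "open" are said of these compounds alone.

Measured compounds:
- compound 1 `O=C1c2c[n+]([O-])c3ccccc3c2C(=O)c2[nH]c3ccccc3c21`: in a toxicity assay on L02 cells (Homo sapiens) for cytotoxicity, read by MTT assay, with a stated time of 72 h (on this read-out higher numbers stand for weaker inhibition and lower numbers for stronger inhibition), compound 1 gives 400 nM
- compound 2 `O=C1c2c[n+]([O-])c3ccccc3c2C(=O)c2c1c1ccccc1n2Cc1cn(CC(O)CO)nn1`: compound 2 gives 1070 nM
- compound 3 `CN1CCN(CCCn2c3c(c4ccccc42)C(=O)c2c[n+]([O-])c4ccccc4c2C3=O)CC1`: compound 3 gives 230 nM

Compound 3 has the lowest number of the three, though against compound 1 the step is a 1.7-fold lower number from compound 1 to compound 3 (0.24 log units; within the scatter) and so does not separate them. Among the compounds with values here, only the step of a 4.7-fold lower number from compound 2 to compound 3 (0.67 log units; beyond the scatter) stands beyond the scatter, and the step of a 2.7-fold higher number from compound 1 to compound 2 (0.43 log units; beyond the scatter) is of the same modest size in the other direction.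

Compound 4 `O=C1c2c[n+]([O-])c3ccccc3c2C(=O)c2c1c1ccccc1n2CCCCn1ccnc1` keeps the shared core and the chain on the aromatic nitrogen of compound 3; the change is (1H-imidazol-1-yl)methyl in place of 4-methylpiperazin-1-yl on a saturated chain carbon, three bonds along the chain from an aromatic nitrogen. Within the data shown here, the step that bears on it is a 4.7-fold lower number from compound 2 to compound 3 (0.67 log units; beyond the scatter), the only measured exchange at the end of that chain, and it was modest. Among the measured compounds shown here, no measured step exchanges one ring-bearing chain end for another of nearly equal size, so the expectation rests on that single modest step and on the small spread of all three numbers. A change in this assay of no more than modest size is expected, leaning toward a higher number, and the estimated step is a 1.5-fold higher number from compound 3 to compound 4 (0.18 log units; within the scatter). Compound 4 is estimated at 350 nM, within 150 nM to 900 nM.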

Compound 4, half-maximal inhibitory concentration: 150 nM
Beside the measured number, compound 4's estimate is 2.3-fold (0.37 log units) above it; the range from low to high includes it.
By their numbers in this assay, from the lowest: compounds 4, 3 and 1 (each within the scatter of the next, the first and the last beyond it); then compound 2.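

In this assay the exchange of 4-methylpiperazin-1-yl for (1H-imidazol-1-yl)methyl on a saturated chain carbon, three bonds along the chain from an aromatic nitrogen, gives a 1.5-fold lower number from compound 3 to compound 4 (0.19 log units; within the scatter) and so does not separate the two chain ends. Unlike the 3-(4-methylpiperazin-1-yl)propyl chain, the 4-(1H-imidazol-1-yl)butyl chain in place of hydrogen on the aromatic nitrogen gives a step beyond the scatter, a 2.7-fold lower number from compound 1 to compound 4 (0.43 log units; beyond the scatter), and 3-(1H-imidazol-1-yl)propyl in place of 1-(2,3-dihydroxypropyl)-1H-1,2,3-triazol-4-yl gives a 7.1-fold lower number from compound 2 to compound 4 (0.85 log units; beyond the scatter). No measurement at hand accounts for these steps.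

Open, going by these compounds, is how a morpholine ring or a primary amine at the same chain end would read in this assay. Also open, on these data alone, is whether a shorter chain carrying the imidazole ring would keep the step from compound 1.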